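Removing a Hydroxyl Group from the Weakest Measured Compound

The source may report more compounds than this note shows. Statements on the series, on what has been measured and on what is new or still open speak of the compounds shown alone.

In an assay on isolated protein for inhibition of ubiquitin carboxyl-terminal hydrolase 7 (Homo sapiens), read by fluorescence, with stated times of 30 min and 1 h (on this read-out lower numbers stand for stronger inhibition and higher numbers for weaker inhibition), compound 2 `O=C([C@H]1Cc2cc(Cl)cc(-c3ccnc4cc(CO)sc34)c2O1)N1CCNCC1` gives 43 nM, the highest of the three measured numbers and so the weakest inhibition shown. Within the data shown here, compound 1 `Cc1cc(Cl)cc(-c2ccnc3cc(CN4C(=O)C5C(C4=O)C5(C)C)sc23)c1C[C@@H]1CNCCO1` gives 0.44 nM and compound 3 `Cc1cc(Cl)cc(-c2ccnc3cc(CN4C(=O)C5C(C4=O)C5(C)C)sc23)c1OC1CCCNC1` gives 2.4 nM; the single measured step, a 5.5-fold higher number from compound 1 to compound 3 (0.74 log units; beyond the scatter), concerns a different part of the shared core and does not involve a hydroxy group. Compound 4 `Cc1cc2nccc(-c3cc(Cl)cc4c3O[C@@H](C(=O)N3CCNCC3)C4)c2s1` differs from compound 2 by hydrogen in place of hydroxy on a saturated chain carbon bound to an aromatic carbon. Among the measured compounds shown here, no measured step bears on this change, so the data give no direction for it. For compound 4 the expected change is small, a 1.4-fold higher number from compound 2 to compound 4 (0.14 log units; within the scatter), in this assay. Compound 4 is estimated at 60 nM, with a range from 20 nM to 200 nM.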

Compound 4, half-maximal inhibitory concentration: 130 nM
Estimate against measurement, compound 4: 2.2-fold (0.34 log units) below; low and high end bracket the measured number.
By their numbers in this assay, from the lowest: compound 1; then compound 3; then compound 2; then compound 4.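

In this assay, hydrogen in place of hydroxy on this saturated chain carbon gives a 3.0-fold higher number from compound 2 to compound 4 (0.48 log units; beyond the scatter), a modest step but one beyond the usual scatter. Among these compounds, this is the first reading at this position, and it shows that hydroxymethyl gives stronger inhibition than methyl here. No measurement available here bears on why the number rises. On these data alone, whether the oxygen itself matters stays open. An amine in place of the hydroxy, or a longer chain such as hydroxyethyl, would test how specific this preference is.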